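Sulfamoylamino to azetidinylsulfonylethyl on the shared core

The source may report more compounds than this note shows. Statements on the series, on what has been measured and on what is new or still open speak of the compounds shown alone.

Compound 1 `NS(=O)(=O)NNc1nonc1/C(=N/O)Nc1ccc(F)c(Br)c1` carries a sulfamoylamino group on a nitrogen on the aromatic ring of the shared core. In an assay on HeLa cells for inhibition of Indoleamine 2,3-dioxygenase 1 (Homo sapiens), read by spectrophotometry, with a stated time of 24 h (on this read-out lower numbers stand for an effect already at smaller amounts and higher numbers for an effect only at larger amounts of compound), compound 1 gives 101 nM. Compound 2 `O=S1(=O)CC(Nc2nonc2/C(=N/O)Nc2ccc(F)c(Br)c2)C1` gives 59 nM and compound 3 `N=S1(=O)CC(Nc2nonc2/C(=N/O)Nc2ccc(F)c(Br)c2)C1` gives 53 nM in this assay, so all three numbers lie within the scatter of one another and compound 1 is not separated from either.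

Compound 4 `O=S(=O)(CCNc1nonc1/C(=N/O)Nc1ccc(F)c(Br)c1)N1CCC1` differs from compound 1 in one place: 2-((azetidin-1-yl)sulfonyl)ethyl in place of sulfamoylamino on a nitrogen on an aromatic ring. Among the measured compounds shown here, the steps that bear on it are a 1.7-fold lower number from compound 1 to compound 2 (0.23 log units; within the scatter) and a 1.9-fold lower number from compound 1 to compound 3 (0.28 log units; within the scatter), each exchanging the sulfamoylamino group for a sulfur-containing four-membered ring; neither moved the number beyond the scatter. Compound 4 also brings in a four-membered ring and a sulfonyl group, so for compound 4 a step of a 1.4-fold lower number from compound 1 to compound 4 (0.16 log units; within the scatter) is expected, that is none beyond the scatter. The estimate for compound 4 in this assay is therefore 70 nM, with a range from 30 nM to 170 nM.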

Compound 4, half-maximal effective concentration: 143 nM
Compound 4: the middle estimate sits 2.0-fold (0.31 log units) below what was measured, and the stated range covers the measured number.
By their numbers in this assay, from the lowest: compounds 3, 2, 1 and 4 (each within the scatter of the next, the first and the last beyond it).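

In this assay, the 2-((azetidin-1-yl)sulfonyl)ethyl group on a nitrogen on an aromatic ring stays level with sulfamoylamino (a 1.4-fold higher number from compound 1 to compound 4 (0.15 log units; within the scatter)), even though it is the larger group, with no hydrogen-bond donors against 2. Among the compounds shown here, it also gives the first steps at this position that reach beyond the scatter, both modest and both against groups of 6 heavy atoms (a 2.4-fold higher number from compound 2 to compound 4 (0.38 log units; beyond the scatter); a 2.7-fold higher number from compound 3 to compound 4 (0.43 log units; beyond the scatter)). Nothing measured on hand accounts for these steps.

The compounds shown do not separate the contribution of the ethyl chain from that of the azetidine ring, a question that a longer propyl chain or a dimethylamino group in place of azetidine would address. On these data alone, how a terminal amine or a carboxylic acid would read at this position also remains open.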